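The source may hold more compounds than are shown below. What is called first, only, known or untested is meant among the compounds shown, and "the series" means these compounds.

For the measured compounds named here, compound 2 `COc1cccc(NC(=O)COc2cc(C)nc3ccc(OC)cc23)c1` gives 35000 nM in a physicochemical assay for solubility, in phosphate buffer, measured as kinetic solubility, with a stated time of 1 h, at pH 7.4 (a higher number here means a more soluble compound, a lower number a less soluble compound), the lowest of the two numbers available; the only other measured compound, compound 1 `COc1ccc2nc(C)cc(OCC(=O)Nc3cccc(C)c3)c2c1`, gives 193000 nM. Going by the values given here, the one measured step, a 5.5-fold lower number from compound 1 to compound 2 (0.74 log units; beyond the scatter), comes from a methoxy in place of a methyl on an aromatic carbon. Compound 3 `COc1ccc2nc(C)cc(OCC(=O)Nc3cc(F)cc(F)c3)c2c1` is not yet measured; it differs from compound 2 by 3,5-difluorophenyl in place of 3-methoxyphenyl on an amide-type nitrogen. Among the compounds with values here, no measured step repeats this exchange of one phenyl group for another, so the nearest guide is only the modest size seen in a 5.5-fold lower number from compound 1 to compound 2 (0.74 log units; beyond the scatter), which concerns a different part of the molecule. On that basis, the expected step for compound 3 is a 1.2-fold lower number from compound 2 to compound 3 (0.07 log units; within the scatter) in this assay, with no confident direction beyond the scatter. The estimate for compound 3 is 30000 nM, within a range from 8000 nM to 120000 nM.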

Compound 3, solubility: 13000 nM
Compound 3: the middle estimate sits 2.3-fold (0.36 log units) above what was measured; the measured number falls inside the stated range.
By their numbers in this assay, from the lowest: compound 3; then compound 2; then compound 1.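

The group on the amide-type nitrogen clearly matters in this assay: there is a 2.7-fold lower number from compound 2 to compound 3 (0.43 log units; beyond the scatter) on replacing 3-methoxyphenyl with 3,5-difluorophenyl, and a 15-fold lower number from compound 1 to compound 3 (1.17 log units; beyond the scatter) on replacing 3-methylphenyl with the same group. Both steps run in the same direction, so among these three compounds the 3,5-difluorophenyl group gives the lowest number, even though 3-methoxyphenyl and 3,5-difluorophenyl have the same count of heavy atoms. Nothing available here explains why the number falls with this change.

Going by these compounds, it remains open where an unsubstituted phenyl or a 3-fluorophenyl would stand, and so whether both fluorines are needed for this fall. Also open, on these data alone, is how a phenyl ring carrying an amine or a carboxylic acid would behave at this place.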